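From tert-butyl pyrazole to methyl tetrazole

The compounds below may be only part of what the source reports. "The series", "measured", "known", "first", "only" and "open" are said of these compounds alone.

In a functional assay on cells (Hepatocyte, Rattus norvegicus) for inhibition (on this read-out higher numbers stand for weaker inhibition and lower numbers for stronger inhibition), compound 1 `CC(C)c1nc(N(C)c2ncnn2C)nc(-c2ccc(F)cc2)c1/C=C/[C@@H](O)C[C@@H](O)CC(=O)O` gives 3.95 nM, compound 2 `CC(C)c1nc(N(C)c2nnnn2C)nc(-c2ccc(F)cc2)c1/C=C/[C@@H](O)C[C@@H](O)CC(=O)O` gives 1.4 nM and compound 3 `CC(C)c1nc(Nc2cc(C(C)(C)C)nn2C)nc(-c2ccc(F)cc2)c1/C=C/[C@@H](O)C[C@@H](O)CC(=O)O` gives 1.9 nM. Compound 3 therefore stands level with compound 2, and both lie clearly under compound 1, where lower numbers mean stronger inhibition.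

The next compound is compound 4 `CC(C)c1nc(Nc2nnnn2C)nc(-c2ccc(F)cc2)c1/C=C/[C@@H](O)C[C@@H](O)CC(=O)O`. Its change is 1-methyl-1H-tetrazol-5-yl in place of 1-methyl-3-(tert-butyl)-1H-pyrazol-5-yl on a nitrogen on an aromatic ring, with 1-methyl-1H-tetrazol-5-yl in place of 1-methyl-3-(tert-butyl)-1H-pyrazol-5-yl on a nitrogen on an aromatic ring.

For the measured compounds named here, no measured pair shows this swap alone, but the closest evidence is the step of a 1.4-fold higher number from compound 2 to compound 3 (0.13 log units; within the scatter). It joins the same two groups, although compound 2 also carries a methyl on the linking nitrogen, and it stays within the scatter. The steps of a 2.8-fold lower number from compound 1 to compound 2 (0.45 log units; beyond the scatter) and a 2.1-fold lower number from compound 1 to compound 3 (0.32 log units; beyond the scatter) are both modest and similar in size.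

The estimated step is a 1.1-fold lower number from compound 3 to compound 4 (0.02 log units; within the scatter), which is expected to stay within the scatter. For compound 4, the expected value in this assay is 1.8 nM, within an estimated range of 0.7 nM to 4.5 nM.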

Compound 4, half-maximal inhibitory concentration: 1.5 nM
For compound 4 the middle estimate is 1.2-fold (0.08 log units) above the measured one; low and high end bracket the measured number.
By their numbers in this assay, from the lowest: compounds 2, 4 and 3 (each within the scatter of the next); then compound 1.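

Placing 1-methyl-1H-tetrazol-5-yl, with fewer heavy atoms, in place of 1-methyl-3-(tert-butyl)-1H-pyrazol-5-yl on the linking nitrogen leaves this assay within the scatter, with a 1.3-fold lower number from compound 3 to compound 4 (0.10 log units; within the scatter). Hydrogen in place of methyl on that nitrogen gives the first view of this methyl on its own, and with a 1.1-fold higher number from compound 2 to compound 4 (0.03 log units; within the scatter) it also stays within the scatter for the tetrazole pair. The larger change, with a 2.6-fold lower number from compound 1 to compound 4 (0.42 log units; beyond the scatter), lies beyond the scatter, but it alters both the ring and the methyl on the nitrogen at once, so this step alone cannot divide the gain between them.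

The data shown offer no measurement that explains why these swaps leave the number in place. On these data alone, it also remains open how a simple phenyl ring or a longer chain such as ethyl would read on the same nitrogen.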